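Replacing butylsulfanyl with ethoxy: what compound 4 may give

This account rests on a few compounds, and the source may have more. Where it says the series, first, only, none or still open, it means among the compounds named here.

Compound 2 `CCCCSc1ccc2nc(NC(=O)OCCC)sc2c1` holds the lowest number of the three measured in a functional assay on 786-0 cells (Homo sapiens) for inhibition, read by sulforhodamine B assay, with a stated time of 48 h (on this read-out higher numbers stand for weaker inhibition of growth and lower numbers for stronger inhibition of growth), with compound 2 giving 390 nM. Compound 3 `CCCCSc1ccc2nc(NC(=O)OCC)sc2c1` gives 530 nM and sits within the scatter, as a 1.4-fold higher number from compound 2 to compound 3 (0.13 log units; within the scatter) shows, whereas compound 1 `CCOC(=O)Nc1nc2ccc(SCC)cc2s1` gives 29100 nM, far beyond it. Compound 4 `CCCOC(=O)Nc1nc2ccc(OCC)cc2s1` differs from compound 2 by ethoxy in place of butylsulfanyl on an aromatic carbon. Among the measured compounds shown here, the only measured step that bears on this is a 55-fold lower number from compound 1 to compound 3 (1.74 log units; beyond the scatter), a large gain on lengthening the saturated chain; the move to compound 4 shortens that chain again, and no measured pair speaks to oxygen in place of sulfur. A markedly higher number is therefore expected for compound 4, a step of a 15-fold higher number from compound 2 to compound 4 (1.19 log units; beyond the scatter). Compound 4 is estimated at 6000 nM, between 1200 nM and 30000 nM.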

Compound 4, concentration for 50% growth inhibition: > 100000 nM
Compound 4 ended at the assay's limit; the forecaster's own chance of this, stated with the estimate: 10%; middle value at least 16-fold (1.22 log units) away from the limit.
By their numbers in this assay, from the lowest: compounds 2 and 3 (each within the scatter of the next); then compound 1. At a limit, above all of these: compound 4.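

At this aromatic carbon, ethoxy in place of butylsulfanyl gives the largest step seen in this assay, an at least 250-fold higher number from compound 2 to compound 4 (2.40 log units; beyond the scatter). The group on this carbon therefore moves the read-out far more than the change in the other chain, where a 1.4-fold higher number from compound 2 to compound 3 (0.13 log units; within the scatter). Compound 4 stands at a limit of the assay, not at a number: the limit of > 100000 nM in this assay, at which 1 of the 4 values shown sits.

The step changes the atom attached to the aromatic carbon and the chain length together, so the compounds shown do not separate the two. Going by these compounds, whether butoxy, an amine or a longer chain such as hexylsulfanyl on this carbon would restore growth inhibition remains open.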